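A few compounds are considered here, and "the series" means these few. Any claim that something is new, unique, unknown or untested is made for them only; others in the source may bear on it.

Compound 1, `CC(=O)N1N=C(c2cc(Cl)ccc2N)SC1(C)C`, carries a hydrogen on the saturated chain carbon bound to the carbonyl carbon. In an assay on isolated protein for inhibition of Nitric oxide synthase, inducible (Homo sapiens), read by scintillation counting, with a stated time of 30 min, tested at 50 uM (on this read-out higher numbers stand for more inhibition at the one concentration tested (going by the name of the read-out) and lower numbers for less inhibition), compound 1 gives 72.8%. Compound 2, `CCCCC(=O)N1N=C(c2cc(Cl)ccc2N)SC1(C)C`, has a propyl there instead, and in this assay compound 2 gives 12.6%. For the measured compounds named here, the one measured step, a number 60.2 percentage points lower from compound 1 to compound 2 (beyond the scatter), leaves compound 2 with the lower of the two numbers seen so far. Compound 3, `CC1(C)SC(c2cc(Cl)ccc2N)=NN1C(=O)C1CCC1`, differs from compound 2 by cyclobutyl in place of butyl on a carbonyl carbon. Going by the values given here, no measured step exchanges a chain for a ring of the same atom count, so the step from compound 1 to compound 2 is only a loose guide here; it shows that lengthening the chain at this carbonyl carbon lowered the reading sharply, but says nothing about closing that chain into a ring. For compound 3 a reading near that of compound 2 is therefore expected, with a step of a number 5.4 percentage points higher from compound 2 to compound 3 (within the scatter) in this assay, within the scatter and of uncertain direction. The estimate for compound 3 is 18%, ranging from 0% to 45%.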

Compound 3, a percentage reported as inhibition, at one concentration (the size of the read-out at that concentration, not a potency): -4.65%
Beside the measured number, compound 3's estimate is 22.7 percentage points above it; measured number below the stated range.
By their numbers in this assay, from the lowest: compound 3; then compound 2; then compound 1.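

Closing the chain into a ring did not restore the reading. In this assay the change from butyl to cyclobutyl on this carbonyl carbon is a number 17.3 percentage points lower from compound 2 to compound 3 (beyond the scatter) and shows that two groups with the same count of heavy atoms need not read alike here. Measured against methyl, the cyclobutyl change is a number 77.5 percentage points lower from compound 1 to compound 3 (beyond the scatter) and shows that the open chain and the ring shown both fall well short of compound 1, although nothing available explains the lower reading of the ring.

The compounds shown cover only methyl, butyl and cyclobutyl on this carbonyl carbon. Going by these compounds, how a cyclopropyl, a phenyl or a butyl chain ending in an amine would read there remains open, as does whether any group can read above compound 1.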